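This account rests on a few compounds, and the source may have more. Where it says the series, first, only, none or still open, it means among the compounds named here.

Compound 1 `CN(C)c1ccc(C(=O)N2CCC(NS(=O)(=O)c3cc(S(=O)(=O)c4ccccc4)ccc3C(F)(F)F)CC2)cc1`: 190 nM in an assay on U2OS cells for inhibition of secreted frizzled-related protein 1 (Homo sapiens), read by a luciferase reporter, with a stated time of 18 h; on this read-out lower numbers stand for an effect already at smaller amounts and higher numbers for an effect only at larger amounts of compound
Compound 2 `O=C(O)c1ccc(N2CCC(NS(=O)(=O)c3cc(S(=O)(=O)c4ccccc4)ccc3C(F)(F)F)CC2)cc1`: 230 nM

Compound 2 gives the highest of the two numbers in this assay, though the step of a 1.2-fold higher number from compound 1 to compound 2 (0.08 log units; within the scatter) lies within the scatter. Compound 3 `O=C(O)CCCC(=O)N1CCC(NS(=O)(=O)c2cc(S(=O)(=O)c3ccccc3)ccc2C(F)(F)F)CC1` differs from compound 2 by (3-carboxypropyl)carbonyl in place of 4-carboxyphenyl on an amine nitrogen in a ring. Going by the values given here, only that one measured step bears on the new change, and it shows that swapping the group on the ring nitrogen left the number essentially unchanged. Among the compounds with values here, compound 3 is therefore expected to show no step beyond the scatter, a 1.4-fold higher number from compound 2 to compound 3 (0.14 log units; within the scatter), with a wide range since no measured compound lacks the aromatic ring at this position. Compound 3 is estimated at 320 nM, between 100 nM and 1100 nM.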

Compound 3, half-maximal effective concentration: 570 nM
Compound 3: the middle estimate sits 1.8-fold (0.25 log units) below what was measured, and the stated range covers the measured number.
By their numbers in this assay, from the lowest: compounds 1 and 2 (each within the scatter of the next); then compound 3.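

This position responds to the group it carries: in this assay, (3-carboxypropyl)carbonyl in place of 4-carboxyphenyl gives a 2.5-fold higher number from compound 2 to compound 3 (0.39 log units; beyond the scatter), and 3-carboxypropyl in place of 4-(dimethylamino)phenyl on the carbonyl carbon gives a 3.0-fold higher number from compound 1 to compound 3 (0.48 log units; beyond the scatter). The two groups with an aromatic ring, which could not be told apart, thus both give lower numbers than this group with no ring, though only by modest steps. Nothing at hand explains this shift.

On these data alone, whether a chain ending in an amine, or a longer chain ending in a carboxylic acid, would return the number to that of the aromatic groups stays open. So does the effect of a plain benzoyl group here.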